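Aryl Swap on a Shared Core: No Shift Expected

The compounds below may be only part of what the source reports. "The series", "measured", "known", "first", "only" and "open" are said of these compounds alone.

Of the compounds shown here, three sharing one core have been measured in an assay on CHO cells for displacement of a labelled ligand from adenosine receptor A1 (Homo sapiens), read by scintillation counting, tested at 10 uM; on this read-out higher numbers stand for more inhibition at the one concentration tested (going by the name of the read-out) and lower numbers for less inhibition. Compound 3 `CC(C)(C)Cc1c(Br)sc(N)c1C(=O)c1cccc(Cl)c1` gives 1%. Compound 1 `Cc1ccc(C(=O)c2c(CC(C)(C)C)csc2N)cc1` gives 1%, and compound 2 `CC(C)(C)Cc1c(Br)sc(N)c1C(=O)c1ccc(Cl)cc1` gives 1%, so compound 3 stands level with both within the usual scatter. Among the compounds with values here, the single step between measured compounds, no change at the digits printed from compound 2 to compound 3 (within the scatter), shows that changing 4-chlorophenyl to 3-chlorophenyl on the carbonyl carbon made no difference beyond the scatter.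

Compound 4 `Cc1ccc(C(=O)c2c(N)sc(Br)c2CC(C)(C)C)cc1` has not yet been measured. It differs from compound 3 by 4-methylphenyl in place of 3-chlorophenyl on a carbonyl carbon. Compound 1 also carries a 4-methylphenyl on a carbonyl carbon and gives 1%. Within the data shown here, every measured value sits at the same low level and the one measured step was flat, so nothing points to a change here. The step expected from compound 3 to compound 4, a number 1 percentage points higher from compound 3 to compound 4 (within the scatter), is therefore estimated to be nothing beyond the scatter. Compound 4 is expected to give about 2%, with a likely range from -8% to 12%.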

Compound 4, a percentage reported as inhibition, at one concentration (the size of the read-out at that concentration, not a potency): 1%
Compound 4: the middle estimate sits 1 percentage points above what was measured; measured number inside the range.
By their numbers in this assay, from the lowest: compounds 1, 2, 3 and 4 (each within the scatter of the next).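

With 4-methylphenyl in place of 3-chlorophenyl on a carbonyl carbon, this assay shows no change at the digits printed from compound 3 to compound 4 (within the scatter) and so the flat result at this position now extends beyond moving the chloro group to replacing it with a different substituent. Methyl in place of chloro on an aromatic carbon gives no change at the digits printed from compound 2 to compound 4 (within the scatter) while bromo in place of hydrogen on an aromatic carbon, a change on the shared core and not on the group attached to the carbonyl carbon, gives no change at the digits printed from compound 1 to compound 4 (within the scatter) and adds a second changed place to the picture. Nothing available explains why these readings stay level.

From the compounds shown here alone, whether an amine or a carboxylic acid on the phenyl ring would give a different reading remains open. So does the outcome of putting a longer chain in place of the bromo.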